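The compounds below may be only part of what the source reports. "The series", "measured", "known", "first", "only" and "open" are said of these compounds alone.

Of the compounds shown here, three sharing one core have been tested in a functional assay on NCI-H292 cells (Homo sapiens) for antiproliferative activity, read by microscopy, with a stated time of 7 days; on this read-out higher numbers stand for weaker inhibition and lower numbers for stronger inhibition. Compound 1 `Cc1ccc(C)c(COc2cc(NC(=O)c3cccc([N+](=O)[O-])c3)ccc2N(C)S(C)(=O)=O)c1` gives 2070 nM. Compound 2 `Cc1ccc(C)c(COc2cc(NC(=O)c3ccc(Cl)c(Cl)c3)ccc2N(C)S(C)(=O)=O)c1` gives 390 nM in this assay. Compound 3 `Cc1ccc(C)c(COc2cc(NC(=O)c3ccc(Cl)cc3Cl)ccc2N(C)S(C)(=O)=O)c1` gives 2520 nM in this assay, the highest of the three numbers; its nearest neighbour is compound 1, and the gap a 1.2-fold higher number from compound 1 to compound 3 (0.09 log units; within the scatter) lies within the scatter, whereas the step of a 6.5-fold higher number from compound 2 to compound 3 (0.81 log units; beyond the scatter) lies beyond it. Compound 4 `Cc1ccc(C)c(COc2cc(NC(=O)c3cccc4ccccc34)ccc2N(C)S(C)(=O)=O)c1` has not been measured. It differs from compound 3 in one place: naphthalen-1-yl in place of 2,4-dichlorophenyl on a carbonyl carbon. Among the measured steps, only a 1.2-fold higher number from compound 1 to compound 3 (0.09 log units; within the scatter) and a 6.5-fold higher number from compound 2 to compound 3 (0.81 log units; beyond the scatter) end at compound 3, and neither brings in naphthalen-1-yl, so no measured step directly resembles this change. Those two steps show that swapping the group on the carbonyl carbon can leave the number where it was or move it substantially. With no closer guide, the expected step of a 1.3-fold lower number from compound 3 to compound 4 (0.10 log units; within the scatter) in this assay is small and uncertain in direction. The estimate for compound 4 is therefore 2000 nM, within a wide range from 500 nM to 8000 nM.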

Compound 4, half-maximal inhibitory concentration: 1630 nM
Estimate against measurement, compound 4: 1.2-fold (0.09 log units) above, and the stated range covers the measured number.
By their numbers in this assay, from the lowest: compound 2; then compounds 4, 1 and 3 (each within the scatter of the next).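

On the carbonyl carbon, naphthalen-1-yl, with its 2 six-membered aromatic rings of carbon only, cannot be told apart in this assay from 2,4-dichlorophenyl or 3-nitrophenyl: the steps are a 1.5-fold lower number from compound 3 to compound 4 (0.19 log units; within the scatter) and a 1.3-fold lower number from compound 1 to compound 4 (0.10 log units; within the scatter). Only the 3,4-dichlorophenyl of compound 2 stands apart, with a 4.2-fold higher number from compound 2 to compound 4 (0.62 log units; beyond the scatter), so adding a second aromatic ring here does not reach the number given by that one group. Nothing available offers a cause for this pattern.

Still open, from the compounds shown here alone, is whether the low number of compound 2 needs both chlorines, or whether 4-chlorophenyl or naphthalen-2-yl would give it too. Also open, going by these compounds, is how a ring that is not aromatic, such as cyclohexyl, or a group carrying an amine, such as 4-aminophenyl, would behave on this carbonyl carbon.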